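A 4-nitrophenyl swap on compound 3

The source may report more compounds than this note shows. Statements on the series, on what has been measured and on what is new or still open speak of the compounds shown alone.

Measured so far in a functional assay on HCT-116 cells (Homo sapiens) for antiproliferative activity, read by MTT assay, with a stated time of 72 h; on this read-out lower numbers stand for stronger inhibition and higher numbers for weaker inhibition
compound 1 `Cc1ccc(N2CCN(C(=S)SCc3ccc4nc(N)nc(N)c4c3)CC2)cc1` gives 5510 nM
compound 2 `Cc1ccccc1N1CCN(C(=S)SCc2ccc3nc(N)nc(N)c3c2)CC1` gives 11800 nM
compound 3 `Nc1nc(N)c2cc(CSC(=S)N3CCN(c4ccc(Cl)c(Cl)c4)CC3)ccc2n1` gives 6680 nM

Compound 3 stands within the scatter of both compound 1 and compound 2, although those two are set apart by a 2.1-fold higher number from compound 1 to compound 2 (0.33 log units; beyond the scatter), a modest step. Compound 4 `Nc1nc(N)c2cc(CSC(=S)N3CCN(c4ccc([N+](=O)[O-])cc4)CC3)ccc2n1` carries the next change, (4-nitrophenyl in place of 3,4-dichlorophenyl on an amine nitrogen in a ring), with 4-nitrophenyl in place of 3,4-dichlorophenyl on an amine nitrogen in a ring. Two further measured swaps at this place bear on it, a 1.2-fold higher number from compound 1 to compound 3 (0.08 log units; within the scatter) and a 1.8-fold lower number from compound 2 to compound 3 (0.25 log units; within the scatter), both within the scatter. Among the measured compounds shown here, no compound with 4-nitrophenyl has been measured yet, so these swaps are only a limited guide. In this assay the expected outcome is a 1.0-fold lower number from compound 3 to compound 4 (0.01 log units; within the scatter), with no step beyond the scatter. For compound 4 the estimated value is 6500 nM, with an expected range of 3000 nM to 14000 nM in this read-out.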

Compound 4, half-maximal inhibitory concentration: 4680 nM
For compound 4 the middle estimate is 1.4-fold (0.14 log units) above the measured one; low and high end bracket the measured number.
By their numbers in this assay, from the lowest: compounds 4, 1, 3 and 2 (each within the scatter of the next, the first and the last beyond it).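

In this assay, a 4-nitrophenyl group, which brings 2 hydrogen-bond acceptors to the amine nitrogen in the ring, leaves the number within the scatter of both earlier para-free comparisons: a 1.4-fold lower number from compound 3 to compound 4 (0.15 log units; within the scatter) and a 1.2-fold lower number from compound 1 to compound 4 (0.07 log units; within the scatter). Among the compounds shown here, the only step beyond the scatter is modest: a 2.5-fold lower number from compound 2 to compound 4 (0.40 log units; beyond the scatter). Nothing measured explains these readings. Going by these compounds, whether an amine or a carboxylic acid on this phenyl ring would also leave the number in this range remains open.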